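Swapping the Amide Substituent: From Compound 1 to Compound 3

A few compounds are considered here, and "the series" means these few. Any claim that something is new, unique, unknown or untested is made for them only; others in the source may bear on it.

Measured compounds:
Compound 1, `CCn1c(C(=O)NCCN(C)C)ccc1C(CC)(CC)c1ccc(OCCC(O)(CC)CC)c(C)c1`, gives 82 nM in an assay on cells for agonist activity at vitamin D3 receptor (Homo sapiens), with a stated time of 96 h; a lower number here means that less compound is needed, a higher number that more compound is needed for the effect.
Compound 2, `CCn1c(C(=O)NCC#N)ccc1C(CC)(CC)c1ccc(OCCC(O)(CC)CC)c(C)c1`, gives 1080 nM in this assay.

Of the two numbers shown, compound 1 has the lower one, and compound 2 is its only neighbour. For the measured compounds named here, the single measured step between them is a 13-fold higher number from compound 1 to compound 2 (1.12 log units; beyond the scatter), and it arises from exchanging the group carried on the amide nitrogen of compound 1 for a much smaller one.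

Compound 3, `CCC(C)C(NC(=O)c1ccc(C(CC)(CC)c2ccc(OCCC(O)(CC)CC)c(C)c2)n1CC)C(=O)O`, has not yet been measured in this assay. It differs from compound 1 in one place: 1-carboxy-2-methylbutyl in place of 2-(dimethylamino)ethyl on an amide-type nitrogen. Going by the values given here, the same position is the one altered in the step from compound 1 to compound 2, and that step was large. Among the compounds with values here, the group entering in compound 3 is not the one that entered in compound 2, so the earlier step offers only a direction, not a size. Still, removing the 2-(dimethylamino)ethyl group has so far cost a great deal, so a higher number is expected for compound 3, probably smaller than the step to compound 2 but clearly beyond the scatter. Compound 3 is therefore estimated to give 400 nM, within 80 nM to 2000 nM. For compound 3 this estimate amounts to a 4.9-fold higher number from compound 1 to compound 3 (0.69 log units; beyond the scatter).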

Compound 3, half-maximal effective concentration: 860 nM
Compound 3: middle estimate off by 2.2-fold (0.33 log units), on the low side, and the stated range covers the measured number.
By their numbers in this assay, from the lowest: compound 1; then compounds 3 and 2 (each within the scatter of the next).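

In this assay the exchange of 2-(dimethylamino)ethyl for 1-carboxy-2-methylbutyl on the amide-type nitrogen gives a 10-fold higher number from compound 1 to compound 3 (1.02 log units; beyond the scatter), so the large loss at this position is not peculiar to the cyanomethyl group; a second, quite different group brings it too. The two replacements compare as a 1.3-fold lower number from compound 2 to compound 3 (0.10 log units; within the scatter), which means they cannot be told apart here, even though one ends in a nitrile and the other in a carboxylic acid, and the 2-(dimethylamino)ethyl group alone stands clearly apart among the three. Nothing given here explains why these changes act as they do.

As far as these compounds go, what remains open is whether the low number of compound 1 rests on the dimethylamino end of its group, on the length of the chain that carries it, or on both. A plain alkyl chain with no amine, a longer chain ending in the same dimethylamino group, or a different amine such as a pyrrolidine at the end of the chain would help to separate these possibilities, and none of them stands among the compounds shown.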